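Swapping the group on the sulfonyl sulfur of compound 3

The source may report more compounds than this note shows. Statements on the series, on what has been measured and on what is new or still open speak of the compounds shown alone.

Compound 1 `CC(O)(C(=O)Nc1ccc(S(=O)(=O)c2ccccc2)c(C#N)c1)C(F)(F)F` gives 3800 nM in a functional assay (Cavia porcellus) with sulfonylurea receptors; K-ATP channels (Homo sapiens) as the target; a higher number here means a weaker inhibitor, a lower number a stronger inhibitor.
Compound 2 `CC(O)(C(=O)Nc1ccc(C#N)c(Sc2ccccc2)c1)C(F)(F)F` gives 8300 nM in this assay.
Compound 3 `COc1ccccc1S(=O)(=O)c1ccc(NC(=O)C(C)(O)C(F)(F)F)cc1` gives 1600 nM in this assay.

Among the three measured compounds, compound 3 has the lowest number in this assay and is therefore the strongest inhibitor of the set; its gap to compound 1 and its gap to compound 2 both lie beyond the scatter. No two of these compounds differ in only one place, so no single-change step can be read from them.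

Compound 4 `CC(O)(C(=O)Nc1ccc(S(=O)(=O)c2cncs2)cc1)C(F)(F)F` has not yet been measured. It differs from compound 3 in one place: 1,3-thiazol-5-yl in place of 2-methoxyphenyl on a sulfonyl sulfur. Among the measured compounds shown here, nothing among the measured compounds shows how such a change on the sulfonyl sulfur affects the result, so the expectation rests on compound 3 alone.

The author expects the number for compound 4 to rise moderately, by a step of a 2.2-fold higher number from compound 3 to compound 4 (0.34 log units; beyond the scatter) beyond the scatter. Compound 4 is estimated at 3500 nM, with a range from 1200 nM to 10000 nM.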

Compound 4, half-maximal inhibitory concentration: 7700 nM
Compound 4: middle estimate off by 2.2-fold (0.34 log units), on the low side; the measured number falls inside the stated range.
By their numbers in this assay, from the lowest: compound 3; then compound 1; then compounds 4 and 2 (each within the scatter of the next).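

Among the compounds shown here, replacing 2-methoxyphenyl with 1,3-thiazol-5-yl on the sulfonyl sulfur gives a 4.8-fold higher number from compound 3 to compound 4 (0.68 log units; beyond the scatter) in this assay, the first single-change reading at this position. It shows that the group on this sulfur affects the result, and that this exchange yields a weaker inhibitor. Ring size, hetero atoms and acceptor count all change together in this one swap, and no available evidence accounts for the step or separates these differences.

The compounds shown leave open whether the gap follows from the ring itself or from the methoxy group that leaves with it, a question that a plain phenyl group on the same sulfur could address. They also leave open how a pyridine ring or a small alkyl chain would fare at this position on the shared core.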